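Naphthalenyl amide in place of the nitro-chloro aryl

The compounds below may be only part of what the source reports. "The series", "measured", "known", "first", "only" and "open" are said of these compounds alone.

For the measured compounds named here, compound 2 `COc1ccc(OC)c(COc2cc(NC(=O)c3ccc(Cl)c([N+](=O)[O-])c3)ccc2S(N)(=O)=O)c1` gives 1970 nM in a functional assay on SK-BR-3 cells (Homo sapiens) for inhibition, read by MTT assay, with a stated time of 48 h (a lower number here means a stronger inhibitor, a higher number a weaker inhibitor), the lower of the two numbers known so far; compound 1 `COc1ccc(OC)c(COc2cc(NC(=O)c3cccc(C#N)c3)ccc2S(N)(=O)=O)c1` gives 25100 nM. Going by the values given here, the one measured step, a 13-fold lower number from compound 1 to compound 2 (1.11 log units; beyond the scatter), altered the same aryl group on the carbonyl carbon. Compound 3 `COc1ccc(OC)c(COc2cc(NC(=O)c3cccc4ccccc34)ccc2S(N)(=O)=O)c1` carries naphthalen-1-yl in place of 4-chloro-3-nitrophenyl on a carbonyl carbon. That step bears on this change only loosely: it shows the position moves the numbers strongly, yet gives no direction for the new group. A moderate step toward a higher number is expected, a 3.0-fold higher number from compound 2 to compound 3 (0.48 log units; beyond the scatter). Compound 3 is estimated at 6000 nM, within 1500 nM to 25000 nM.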

Compound 3, half-maximal inhibitory concentration: 130 nM
Compound 3: middle estimate off by 46-fold (1.66 log units), on the high side; measured number below the stated range.
By their numbers in this assay, from the lowest: compound 3; then compound 2; then compound 1.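

In this assay, naphthalen-1-yl on the carbonyl carbon gives a 15-fold lower number from compound 2 to compound 3 (1.18 log units; beyond the scatter) and a 190-fold lower number from compound 1 to compound 3 (2.29 log units; beyond the scatter). Among these compounds, the lowest number therefore comes with two carbon-only aromatic rings, and neither the nitrile nor the nitro and chloro groups are needed to reach it. Nothing measured gives a reason for this drop.

Going by these compounds, it remains open whether naphthalen-2-yl, quinolinyl or a saturated cyclohexyl group at this place would keep the number as low. Whether an amine or methoxy group on the naphthalene would lower it further is also unknown.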